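Chloro substitution in a bis-amide series: working notes

A few compounds are considered here, and "the series" means these few. Any claim that something is new, unique, unknown or untested is made for them only; others in the source may bear on it.

compound 1 `O=C(CC(CC(=O)NC1Cc2ccccc2C1)c1ccc(Cl)cc1)NCCN1CCCCC1`: 86200 nM
compound 2 `O=C(CC(CC(=O)NC1Cc2ccccc2C1)c1ccccc1)NCCN1CCCCC1`: > 100000 nM (a limit)
compound 3 `CN(C(=O)CC(CC(=O)NCCN1CCCC1)c1ccccc1)C1Cc2ccccc2C1`: > 100000 nM (a limit)

In a functional assay on HeLa cells (Homo sapiens) for inhibition (a lower number here means a stronger inhibitor, a higher number a weaker inhibitor), compound 1 gives 86200 nM. For compound 2 this assay reports only a limit, > 100000 nM. For compound 3 it likewise reports only a limit, > 100000 nM. Both of these values sit at the limit of > 100000 nM in this assay, at which 2 of the 3 values shown sit.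

Compound 2 to compound 1 is chloro in place of hydrogen on an aromatic carbon, and the step is an at least 1.1-fold lower number from compound 2 to compound 1 (0.06 log units; that floor lies within the scatter). The difference between the core of compound 3 and that of compound 2 is not broken down here.

Compound 4 `CN(C(=O)CC(CC(=O)NCCN1CCCC1)c1ccc(Cl)cc1)C1Cc2ccccc2C1` is not yet measured. It differs from compound 3 by chloro in place of hydrogen on an aromatic carbon, the same change at the same place as before. Because an at least 1.1-fold lower number from compound 2 to compound 1 (0.06 log units; that floor lies within the scatter) lies within the scatter, compound 4 is expected to stay near the limit, with an estimate of 100000 nM between 40000 nM and 300000 nM. That estimate means an expected step of a number no higher from compound 3 to compound 4 (the limit leaves the size open).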

Compound 4, half-maximal inhibitory concentration: 55400 nM
Compound 4: the middle estimate sits 1.8-fold (0.26 log units) above what was measured; low and high end bracket the measured number.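

In this assay, phenyl to 4-chlorophenyl on the core of compound 3 gives an at least 1.8-fold lower number from compound 3 to compound 4 (0.25 log units; that floor lies within the scatter). Set beside the earlier step, the change runs in the same direction on both cores, with its size left open: the same change on two cores in this assay, an at least 1.1-fold lower number (0.06 log units; that floor lies within the scatter) from compound 2 to compound 1 and an at least 1.8-fold lower number (0.25 log units; that floor lies within the scatter) from compound 3 to compound 4; the limit leaves it open whether they differ. This shows that chloro at this place is compatible with a measurable value on both cores, but both steps start from a limit, so it does not show a gain beyond the scatter or that the step keeps its size from one core to the other.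

Going by these compounds, whether bromo, methoxy or trifluoromethyl at the same place would carry over between the cores stays open. So does the size of the chloro step on either core.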